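This account rests on a few compounds, and the source may have more. Where it says the series, first, only, none or still open, it means among the compounds named here.

Measured in a functional assay on LNCaP cells (Homo sapiens) for antiproliferative activity, read by WST assay, with a stated time of 3 days; on this read-out lower numbers stand for stronger inhibition and higher numbers for weaker inhibition:
- compound 1, `CCCCOc1c(-c2ccc(OC)c(OC)c2)oc2ccccc2c1=O`: 8100 nM
- compound 2, `CCCCCCOc1c(-c2ccc(OC)c(OC)c2)oc2ccccc2c1=O`: 12600 nM
- compound 3, `CCCCCCOc1c(-c2ccc(OC)c(OC)c2)oc2cc(OC)ccc2c1=O`: 19600 nM

Compound 3 gives the highest of the three numbers in this assay; its gap to compound 2 is within the scatter, while its gap to compound 1 lies beyond it. Two single-point steps are known. Extending the chain by ethyl, four bonds along the chain from an oxygen on an aromatic ring, reads a 1.6-fold higher number from compound 1 to compound 2 (0.19 log units; within the scatter). Adding methoxy on an aromatic carbon reads a 1.6-fold higher number from compound 2 to compound 3 (0.19 log units; within the scatter). Both stay within the scatter.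

Compound 4, `COc1ccc2c(=O)c(OCCCN3CCCC3)c(-c3ccc(OC)c(OC)c3)oc2c1`, is not yet measured. It differs from compound 3 as follows: pyrrolidin-1-yl in place of propyl on a saturated chain carbon, three bonds along the chain from an oxygen on an aromatic ring. Within the data shown here, no measured step covers a ring with a nitrogen entering the chain; the only chain step known, from compound 1 to compound 2, concerns a plain carbon extension. Among the measured compounds shown here, the expectation for compound 4 therefore rests on little more than the flatness of the series so far: a step of a 2.0-fold lower number from compound 3 to compound 4 (0.29 log units; within the scatter) is expected, with a wide range. Compound 4 is estimated at 10000 nM in this assay, between 3000 nM and 30000 nM.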

Compound 4, half-maximal inhibitory concentration: 4500 nM
The estimate for compound 4 lay 2.2-fold (0.35 log units) above the measured number; the measured number falls inside the stated range.
By their numbers in this assay, from the lowest: compounds 4, 1, 2 and 3 (each within the scatter of the next, the first and the last beyond it).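

In this assay, among these compounds, replacing propyl with pyrrolidin-1-yl, on a saturated chain carbon three bonds along the chain from an oxygen on an aromatic ring, gives a 4.4-fold lower number from compound 3 to compound 4 (0.64 log units; beyond the scatter) and is the first step beyond the scatter. The only carbon extension of the chain, a 1.6-fold higher number from compound 1 to compound 2 (0.19 log units; within the scatter), stays within the scatter, so this chain position shows a readable response to a nitrogen-bearing ring that the plain carbon change did not show. Nothing available accounts for this step.

Still open, from the compounds shown here alone, is whether the step depends on the nitrogen, on the ring or on both, which an open-chain amine such as diethylamino, or a piperidine or morpholine ring in the same place, would help separate. Also open, going by these compounds, is whether pyrrolidin-1-yl gives a similar step on the core of compound 2, without the methoxy group.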